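Bromo in Place of Fluoro on the Aryl of Compound 3

The source may hold more compounds than are shown below. What is called first, only, known or untested is meant among the compounds shown, and "the series" means these compounds.

Measured compounds:
compound 1, `Cc1ccc2c(c1)C(=O)/C(=C(\S)N(C)c1ccccc1)C(=O)N2C`, 20%
compound 2, `CN1C(=O)/C(=C(/S)N(C)c2ccc(OC(F)(F)F)cc2)C(=O)c2cc(Cl)ccc21`, 39%
compound 3, `CN1C(=O)/C(=C(/S)N(C)c2ccc(F)cc2)C(=O)c2cc(Cl)ccc21`, 54%

In a functional assay on the whole organism for inhibition, with Mus musculus as the target, at a dose of 10 mg/kg by the oral route (on this read-out higher numbers stand for more inhibition at the one dose given (going by the name of the read-out) and lower numbers for less inhibition), compound 3 stands highest of the three numbers, and its separation from compound 2 and from compound 1 lies beyond the scatter in each case. Within the data shown here, the only one-place step among the measured compounds runs to compound 3 itself: a number 15 percentage points higher from compound 2 to compound 3 (beyond the scatter), where fluoro replaced trifluoromethoxy on the aromatic carbon. Compound 1 differs from compound 3 in more than one place, so its lower value shows only that it sits well under compound 3 in this assay.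

Compound 4, `CN1C(=O)/C(=C(/S)N(C)c2ccc(Br)cc2)C(=O)c2cc(Cl)ccc21`, differs from compound 3 by bromo in place of fluoro on an aromatic carbon. Among the measured compounds shown here, no measured step exchanges fluoro for bromo, so the one step that bears on this position, from trifluoromethoxy to fluoro, tells only that the group at this carbon can shift the read-out by a modest margin. With no closer guide, the expected step is a number 4 percentage points lower from compound 3 to compound 4 (within the scatter), which stays within the scatter. Compound 4 is therefore estimated at 50% in this assay, with a range from 30% to 70%.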

Compound 4, a percentage reported as inhibition, in the whole organism at one dose (the size of the read-out at that dose, not a potency): 50%
Beside the measured number, compound 4's estimate shows no gap at the digits printed; measured number inside the range.
By their numbers in this assay, from the lowest: compound 1; then compound 2; then compounds 4 and 3 (each within the scatter of the next).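

In this assay, the change from 4-fluorophenyl to 4-bromophenyl reads as a number 4 percentage points lower from compound 3 to compound 4 (within the scatter) and gives the first direct view of two of these groups exchanged for each other, showing that bromo and fluoro cannot be told apart at this aromatic carbon. Trifluoromethoxy now stands apart from both groups, for alongside the earlier a number 15 percentage points higher from compound 2 to compound 3 (beyond the scatter) there is also a number 11 percentage points higher from compound 2 to compound 4 (beyond the scatter), so two separate replacements at this carbon, both beyond the scatter, point the same way across these three compounds. Nothing available gives a reason for these steps or shows what the two groups share that trifluoromethoxy lacks.

The compounds shown leave open whether a quite different group at this carbon, such as an amine, a carboxylic acid or a longer alkoxy chain, would stay with bromo and fluoro or fall nearer to trifluoromethoxy. They also leave open what the unsubstituted phenyl and the other group on the core of compound 1 each contribute, as that compound differs from the others in more than one place.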